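Chain length on the aromatic amine: toward compound 4

The source may hold more compounds than are shown below. What is called first, only, known or untested is meant among the compounds shown, and "the series" means these compounds.

All numbers here come from an assay on isolated protein for inhibition of Amine oxidase [flavin-containing] A (Homo sapiens), read by fluorescence and Amplex Red, with a stated time of 30 min, tested at 1 nM; a lower number here means a weaker effect, a higher number a stronger effect of the compound at the concentration tested.

compound 1, `COCCNc1nnc(SCC(=O)N(Cc2cccc([N+](=O)[O-])c2)c2ccc(F)cc2)s1`: 26.9%
compound 2, `CCCNc1nnc(SCC(=O)N(Cc2cccc([N+](=O)[O-])c2)c2ccc(F)cc2)s1`: 20.5%
compound 3, `CCNc1nnc(SCC(=O)N(Cc2cccc([N+](=O)[O-])c2)c2ccc(F)cc2)s1`: 21%

Compound 3 sits between the other two, and both of its gaps stay within the scatter: a number 0.5 percentage points higher from compound 2 to compound 3 (within the scatter) and a number 5.9 percentage points lower from compound 1 to compound 3 (within the scatter). The three compounds differ only at the saturated chain carbon two bonds along the chain from the nitrogen on the aromatic ring, and none of the three steps leaves the scatter; a number 6.4 percentage points lower from compound 1 to compound 2 (within the scatter) is the third of them.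

The next compound, compound 4, is `CCCCNc1nnc(SCC(=O)N(Cc2cccc([N+](=O)[O-])c2)c2ccc(F)cc2)s1`. Relative to compound 3 it carries ethyl in place of hydrogen on a saturated chain carbon, two bonds along the chain from a nitrogen on an aromatic ring. The change is at the same place as the steps already seen. The closest comparison is the hydrogen-to-methyl pairing of compound 2 and compound 3, which gave essentially nothing, and the larger swap of methoxy for hydrogen between compound 1 and compound 3 also stayed within the scatter. Going by the values given here, nothing among the measured compounds points to a step beyond the scatter when the chain is lengthened by ethyl here.

Compound 4 is therefore expected to give about 22% in this assay, with a plausible range of 12% to 32%. The step from compound 3 that this estimate implies, a number 1 percentage points higher from compound 3 to compound 4 (within the scatter), is expected to lie within the scatter.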

Compound 4, a percentage reported as inhibition, at one concentration (the size of the read-out at that concentration, not a potency): 19.7%
Compound 4: middle estimate off by 2.3 percentage points, on the high side, and the stated range covers the measured number.
By their numbers in this assay, from the lowest: compounds 4, 2, 3 and 1 (each within the scatter of the next).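

Lengthening the chain to butylamino in compound 4 adds the largest alkyl group in the set, yet in this assay no step to the other three compounds leaves the scatter: (  a number 1.3 percentage points lower from compound 3 to compound 4 (within the scatter)  ), (  a number 0.8 percentage points lower from compound 2 to compound 4 (within the scatter)  ) and, against the methoxy chain, (  a number 7.2 percentage points lower from compound 1 to compound 4 (within the scatter)  ). Ethyl in place of hydrogen on this saturated chain carbon, two bonds along the chain from a nitrogen on an aromatic ring, therefore joins the methyl and methoxy changes in giving no readable difference, and the four compounds show no trend with chain length that can be told apart from the scatter. No measurement at hand accounts for this flat result.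

On these data alone, whether a longer chain such as octyl, a cyclohexyl ring, a primary amine or a carboxylic acid at this place would leave the scatter remains open. Each compound also has a read-out at one concentration only, so the flat result describes the size of the effect at that concentration and says nothing about potency.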